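The compounds below may be only part of what the source reports. "The series", "measured", "known", "first", "only" and "open" are said of these compounds alone.

Measured compounds and values in an assay on cells for agonist activity at vitamin D3 receptor (Homo sapiens), read by microscopy; on this read-out higher numbers stand for an effect only at larger amounts of compound and lower numbers for an effect already at smaller amounts:
- compound 1, `CCN(CC)CCNC(=O)c1ccc(C(CC)(CC)c2ccc(OCC(O)C(C)(C)C)c(C)c2)n1CC`: 6.54 nM
- compound 2, `CCN(CC)CCNC(=O)c1cc(C(CC)(CC)c2ccc(C#CC(O)(CC)CC)c(C)c2)cn1CC`: 6.98 nM
- compound 3, `CCn1cc(C(CC)(CC)c2ccc(C#CC(O)(CC)CC)c(C)c2)cc1C(=O)NCCN(C)C`: 19.3 nM

Compound 3 holds the highest number of the three. Its nearest neighbour is compound 2, and the single-point step between them is a 2.8-fold higher number from compound 2 to compound 3 (0.44 log units; beyond the scatter). Compound 1 lies a little further off; both of these gaps lie beyond the scatter, so compound 3 is the one that needs the largest amount for a half-maximal effect in this assay.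

Compound 4, `CCn1cc(C(CC)(CC)c2ccc(C#CC(O)(CC)CC)c(C)c2)cc1C(=O)OCCO`, is not yet measured. Against compound 3 the change is 2-hydroxyethoxy in place of (2-(dimethylamino)ethyl)amino on a carbonyl carbon. This rewrites the whole amide-side substituent: the group that leaves carries the aminoethyl chain that varied between compound 2 and compound 3, and the group that enters is smaller and without nitrogen.

Going by the values given here, only one measured step touches this part of the molecule, a 2.8-fold higher number from compound 2 to compound 3 (0.44 log units; beyond the scatter), and it covers a much smaller edit than the one from compound 3 to compound 4. Among the compounds with values here, no measured pair shows an ester in place of the amide, so the direction is not fixed by data. Given that the sole nearby step moved the number upward, compound 4 is expected to sit further up again, a 2.3-fold higher number from compound 3 to compound 4 (0.37 log units; beyond the scatter), with a wide margin.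

Estimate for compound 4 in this assay: 45 nM, range 12 nM to 180 nM.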

Compound 4, half-maximal effective concentration: 12.6 nM
Compound 4: the middle estimate sits 3.6-fold (0.55 log units) above what was measured, and the stated range covers the measured number.
By their numbers in this assay, from the lowest: compounds 1, 2, 4 and 3 (each within the scatter of the next, the first and the last beyond it).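

Working notes on the carbonyl substituent, read in this assay: 2-hydroxyethoxy in place of (2-(dimethylamino)ethyl)amino gives a 1.5-fold lower number from compound 3 to compound 4 (0.19 log units; within the scatter), and in place of (2-(diethylamino)ethyl)amino it gives a 1.8-fold higher number from compound 2 to compound 4 (0.26 log units; within the scatter), so neither step separates compound 4 from the compound it is compared with. Going by these compounds alone, this position on the carbonyl carbon therefore tolerates an entering group without nitrogen, and the aminoethyl chain is not a condition for a number of this size in compound 4; the much smaller edit, a 2.8-fold higher number from compound 2 to compound 3 (0.44 log units; beyond the scatter), is the only step here that lies beyond the scatter. No data among those at hand explain this outcome.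

The step from compound 3 to compound 4 changes the atom on the carbonyl carbon and the end of the chain together, so its two parts remain unseparated, and a 2-hydroxyethylamino group on the same carbonyl carbon would tell them apart. As far as these compounds go, how a carboxylic acid or a longer chain such as 3-hydroxypropoxy at this place would read in this assay also stays open.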